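The source may report more compounds than this note shows. Statements on the series, on what has been measured and on what is new or still open speak of the compounds shown alone.

Three compounds have been measured in a physicochemical assay for metabolic stability, read by LC-MS, with a stated time of 38 days, tested at 10 mM; a lower number here means that less of the compound is left, a higher number that more of the compound is left:

Compound 1 `O=C(Nc1nnc(-c2ccncc2)s1)c1cc(-c2ccco2)cc2ccccc12`: 0%
Compound 2 `Cc1ccc(-c2ccc3ccccc3n2)o1`: 102%
Compound 3 `Cc1ccc(-c2cc(C(=O)NC(C)C3CCCO3)c3ccccc3n2)o1`: 55%

Compound 3 stands second highest of the three at 55%. Compound 2 lies higher at 102% and compound 1 lies lower at 0%, and both gaps from compound 3 are beyond the usual scatter.

The next compound to be tested is compound 4 `Cc1ccc(-c2cc(C(=O)NC3CCCCC3)c3ccccc3n2)o1`. It differs from compound 3 in one place: cyclohexyl in place of 1-(oxolan-2-yl)ethyl on an amide-type nitrogen. In words, cyclohexyl stands in place of 1-(oxolan-2-yl)ethyl on an amide-type nitrogen, and the rest of the structure is unchanged.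

Within the data shown here, no pair of measured compounds differs in only one place, so the data do not show directly how such a change plays out in this assay. The expectation therefore starts from compound 3 at 55%, the measured compound that compound 4 resembles. No shift beyond the scatter is expected in either direction. The expected change is a number 5 percentage points higher from compound 3 to compound 4 (within the scatter), a small rise that would stay within the scatter. The wide spread among the three measured values argues for a broad range. For compound 4 the estimated value is 60%, with an expected range from 25% to 95%.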

Compound 4, percent of the compound remaining: 54%
Estimate against measurement, compound 4: 6 percentage points above; low and high end bracket the measured number.
By their numbers in this assay, from the lowest: compound 1; then compounds 4 and 3 (each within the scatter of the next); then compound 2.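

In this assay, among these compounds, the swap of 1-(oxolan-2-yl)ethyl for cyclohexyl on the amide-type nitrogen gives the first single-place comparison, a number 1 percentage points lower from compound 3 to compound 4 (within the scatter), so the read-out does not tell the two compounds apart. The two groups differ in ring size and in what they carry: a five-membered non-aromatic ring with its oxygen, a hydrogen-bond acceptor, stands against a six-membered non-aromatic ring of carbon only, yet this difference leaves no mark beyond the scatter on the percent of the compound remaining, at least for this pair on this core. Nothing in the data offers an account of why the two groups read alike.

The compounds shown leave open whether the read-out would stay equally flat with a group of another kind on the same nitrogen, such as a chain ending in an amine, a chain ending in a carboxylic acid or a longer straight alkyl chain. They also leave open whether the same swap would read alike on the core of compound 1, where the amide-type nitrogen has a different setting.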